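Carboxylic Acid in Place of Tetrazole at the Chain End

The compounds below may be only part of what the source reports. "The series", "measured", "known", "first", "only" and "open" are said of these compounds alone.

Compound 1, `c1ccc2nc(COc3ccc(CCc4nnn[nH]4)cc3)ccc2c1`, in a functional assay (Cavia porcellus) for inhibition of cysteinyl leukotriene receptor (Homo sapiens); a lower number here means a stronger inhibitor, a higher number a weaker inhibitor: 280 nM
Compound 2, `c1ccc2nc(COc3ccc(SCCCc4nnn[nH]4)cc3)ccc2c1`, in this assay: 25 nM
Compound 3, `c1ccc2nc(COc3ccc(OCCCc4nnn[nH]4)cc3)ccc2c1`, in this assay: 250 nM

Three compounds share a core and differ in the chain that carries the acidic group. Compound 3 stands second highest of the three numbers: from compound 1 the step is a 1.1-fold lower number from compound 1 to compound 3 (0.05 log units; within the scatter), whereas from compound 2 the step is a 10-fold higher number from compound 2 to compound 3 (1.00 log units; beyond the scatter). The step of an 11-fold lower number from compound 1 to compound 2 (1.05 log units; beyond the scatter) shows the same gap from the other side.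

Compound 4, `O=C(O)CCCOc1ccc(OCc2ccc3ccccc3n2)cc1`, keeps the chain of compound 3 and changes only its end: carboxy in place of 1H-tetrazol-5-yl on a saturated chain carbon, three bonds along the chain from an oxygen on an aromatic ring. Among the compounds with values here, none of the measured steps touches this group; all three concern the chain alone, and the step from compound 1 to compound 3 stayed within the scatter while the two steps involving compound 2 were larger. Within the data shown here, no measured step therefore tells how this assay responds to the exchange of the acidic group, and the expectation rests on compound 3 alone.

Compound 4 is expected to give 400 nM, between 100 nM and 1600 nM. Among the measured compounds shown here, the estimated step of a 1.6-fold higher number from compound 3 to compound 4 (0.20 log units; within the scatter) is given wide room, since the data hold no step of this kind.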

Compound 4, half-maximal inhibitory concentration: 800 nM
Compound 4: the middle estimate sits 2.0-fold (0.30 log units) below what was measured; measured number inside the range.
By their numbers in this assay, from the lowest: compound 2; then compounds 3 and 1 (each within the scatter of the next); then compound 4.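

In this assay, within the data shown here, the end of the chain proves to matter in its own right: a 3.2-fold higher number from compound 3 to compound 4 (0.51 log units; beyond the scatter) is the first measured step at this position, and it shows that carboxy in place of 1H-tetrazol-5-yl on the same chain does not leave the number unchanged. The two wider steps, a 2.9-fold higher number from compound 1 to compound 4 (0.46 log units; beyond the scatter) and a 32-fold higher number from compound 2 to compound 4 (1.51 log units; beyond the scatter), alter the chain as well as its end, so they place the carboxy compound highest of the four numbers but do not separate the share of each change. Nothing in the available evidence accounts for the difference between these two end groups.

On these data alone, whether the exchange costs as much on the sulfur-linked chain of compound 2, which has the lowest number of the set, remains open, as the carboxy end is seen here only on the chain of compound 3. Also open, as far as these compounds go, is how a primary amide or a methyl ester at the chain end, or a longer chain ending in carboxy, would read in this assay.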